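Can compound 3 recover potency lost by compound 2?

The source may hold more compounds than are shown below. What is called first, only, known or untested is meant among the compounds shown, and "the series" means these compounds.

Measured in a functional assay on PC-3 cells (Homo sapiens) for antiproliferative activity, read by MTT assay, with a stated time of 72 h; on this read-out lower numbers stand for stronger inhibition and higher numbers for weaker inhibition:
- Compound 1 `O=C(N/N=C/c1ccc(F)cc1)Nc1ccc(Oc2ccnc3[nH]ccc23)c(F)c1`: 2330 nM
- Compound 2 `COc1ccc(/C=N/NC(=O)Nc2ccc(Oc3ccnc4[nH]ccc34)c(F)c2)cc1`: 6730 nM

Of these two, compound 2 has the higher number and so is the weaker inhibitor. Among the measured compounds shown here, the only measured step is a 2.9-fold higher number from compound 1 to compound 2 (0.46 log units; beyond the scatter), and it comes from a small change: methoxy in place of fluoro on an aromatic carbon.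

Compound 3 `CN(C)CCn1cccc1/C=N/NC(=O)Nc1ccc(Oc2ccnc3[nH]ccc23)c(F)c1` keeps the shared core but carries a larger change. In it, 1-(2-(dimethylamino)ethyl)-1H-pyrrol-2-yl stands in place of 4-methoxyphenyl on a carbon with a double bond to nitrogen (1-(2-(dimethylamino)ethyl)-1H-pyrrol-2-yl in place of 4-methoxyphenyl on a carbon with a double bond to nitrogen). For the measured compounds named here, no measured compound carries this new group, so one step from a smaller swap is only a rough guide.

Going by the values given here, compound 3 no longer has the methoxy group, and the step of a 2.9-fold higher number from compound 1 to compound 2 (0.46 log units; beyond the scatter) is the only evidence on what that group does here. A modest fall in this assay is therefore expected, although a rise remains possible. The expected change is a 2.2-fold lower number from compound 2 to compound 3 (0.35 log units; beyond the scatter). For compound 3 the estimated value is 3000 nM, with an expected range of 700 nM to 11000 nM.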

Compound 3, half-maximal inhibitory concentration: 1600 nM
Beside the measured number, compound 3's estimate is 1.9-fold (0.27 log units) above it; low and high end bracket the measured number.
By their numbers in this assay, from the lowest: compounds 3 and 1 (each within the scatter of the next); then compound 2.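

Measured by this assay the swap of 4-methoxyphenyl for 1-(2-(dimethylamino)ethyl)-1H-pyrrol-2-yl gives a 4.2-fold lower number from compound 2 to compound 3 (0.62 log units; beyond the scatter) and so shows that this position, on a carbon with a double bond to nitrogen, tolerates much more than a small change on a six-membered aromatic ring of carbon only. Set against the 4-fluorophenyl group of compound 1, the same new group gives a 1.5-fold lower number from compound 1 to compound 3 (0.16 log units; within the scatter) and so recovers what compound 2 gave up, leaving compound 1 and compound 3 impossible to tell apart in this test. No measurement of any property of these groups comes with the numbers, so the reason for the step remains unknown.

The five-membered ring and the dimethylaminoethyl chain enter together, so the compounds shown leave open which of them accounts for the step, a question that 1-methyl-1H-pyrrol-2-yl, with a plain methyl in place of the chain, could help to separate. Also open, on these data alone, is whether a longer chain, or a morpholine in place of the dimethylamino end, would keep the number where it stands or shift it.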